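The compounds below may be only part of what the source reports. "The series", "measured", "known", "first", "only" and "open" are said of these compounds alone.

Measured in a functional assay on HOS-TE85 cells (Homo sapiens) for inhibition, read by CCK-8 assay, with a stated time of 72 h; on this read-out higher numbers stand for weaker inhibition and lower numbers for stronger inhibition:
- Compound 1 `O=C(NCCCCn1cccn1)c1cccc(C2SCC(=O)N2c2cc(Br)ccn2)c1`: 105 nM
- Compound 2 `O=C(NCCCCn1cccn1)c1cccc(C2SCC(=O)N2c2cccnc2)c1`: > 1000 nM

Compound 2 gives > 1000 nM, which is a limit and not a number. It sits at the limit of > 1000 nM in this assay, at which 1 of the 2 values shown sits.

Compound 3 `Cc1ccnc(N2C(=O)CSC2c2cccc(C(=O)NCCCCn3cccn3)c2)c1` has 4-methylpyridin-2-yl in place of pyridin-3-yl on an amide-type nitrogen in a ring.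

For the measured compounds named here, one measured step bears on this change: an at least 9.5-fold higher number from compound 1 to compound 2 (0.97 log units; beyond the scatter), which lies beyond the scatter and has pyridin-3-yl in place of 4-bromopyridin-2-yl at the same place. Going by the values given here, compound 3 reverses the loss of a 4-substituted pyridin-2-yl, though with methyl instead of bromo, and no measured pair compares those two. A step towards stronger inhibition in this assay is therefore expected, ending near compound 1 at 105 nM but probably not fully matching it.

The expected size is an at least 4.5-fold lower number from compound 2 to compound 3 (0.65 log units; beyond the scatter). For compound 3 the estimate is 220 nM, with an expected range of 60 nM to 800 nM.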

Compound 3, half-maximal inhibitory concentration: 19.6 nM
The estimate for compound 3 lay 11-fold (1.05 log units) above the measured number; the measured number lies below the stated range.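

Methyl in place of bromo gives a 5.4-fold lower number from compound 1 to compound 3 (0.73 log units; beyond the scatter) in this assay, so bromo is not needed for strong inhibition here, and on the 4-substituted pyridin-2-yl this direct comparison favours methyl. On the amide-type nitrogen in a ring, 4-methylpyridin-2-yl in place of pyridin-3-yl gives an at least 51-fold lower number from compound 2 to compound 3 (1.70 log units; beyond the scatter), a large step that sets the two groups far apart at this place. For compound 2 the value is a limit and not a number, so this step has a bound rather than a full size: the limit of > 1000 nM in this assay, at which 1 of the 3 values shown sits.

The step from pyridin-3-yl to 4-methylpyridin-2-yl changes both the ring attachment and the 4-substituent, and a plain pyridin-2-yl would be needed to separate the two. From the compounds shown here alone, how 4-ethyl or 4-methoxy on the pyridin-2-yl compares with methyl also stays open.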